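A Benzyl Cap on the Ring Oxygen of Compound 2

The source may hold more compounds than are shown below. What is called first, only, known or untested is meant among the compounds shown, and "the series" means these compounds.

Compound 1, `NCC(N)CCCNC(=O)CCn1cccc(O)c1=O`, gives 35.5% in a physicochemical assay, read by spectrophotometry, with a stated time of 10 min, tested at 0.08 mM, in the presence of a further agent that is not named here; on this read-out lower numbers stand for a weaker effect and higher numbers for a stronger effect at the one concentration tested.
Compound 2, `NCC(N)CCCCNC(=O)CCn1cccc(O)c1=O`, gives 34.9% in this assay.
Compound 3, `Cc1c(O)c(=O)ccn1CCC(=O)NCCCCC(N)CN`, gives 48.4% in this assay.

Among these three numbers compound 2 stands lowest, but its nearest neighbour is compound 1, and the step of a number 0.6 percentage points lower from compound 1 to compound 2 (within the scatter) is within the scatter, so compounds 1 and 2 cannot be told apart on this read-out. Among the measured compounds shown here, compound 3 stands beyond the scatter above compound 2, yet it differs from compound 2 in more than one place, so no single step can be drawn from that pair.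

Compound 4, `NCC(N)CCCCNC(=O)CCn1cccc(OCc2ccccc2)c1=O`, differs from compound 2 by benzyl in place of hydrogen on an oxygen on an aromatic ring. For the measured compounds named here, the one measured step, a number 0.6 percentage points lower from compound 1 to compound 2 (within the scatter), concerns the diamine chain and leaves the oxygen on the aromatic ring untouched; no measured pair changes that oxygen. Nothing measured therefore bears on the change, and the expectation rests on the change alone. The account expects a step of a number 19.9 percentage points lower from compound 2 to compound 4 (beyond the scatter), a fall beyond the scatter, held with a wide range. Compound 4 is estimated at 15%, with a range from 0% to 40%.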

Compound 4, a percentage reported as activity, at one concentration (the size of the read-out at that concentration, not a potency): 19.3%
Compound 4: the middle estimate sits 4.3 percentage points below what was measured, and the stated range covers the measured number.
By their numbers in this assay, from the lowest: compound 4; then compounds 2 and 1 (each within the scatter of the next); then compound 3.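

In this assay, among the compounds shown here, the change from hydroxy to benzyloxy is the first change at this oxygen on the aromatic ring to be measured, and it brings a number 15.6 percentage points lower from compound 2 to compound 4 (beyond the scatter), whereas the only earlier step, a number 0.6 percentage points lower from compound 1 to compound 2 (within the scatter), lay on the diamine chain and could not be told from the scatter. For the compounds shown here, the oxygen is therefore a place where the read-out does respond to a change, which the earlier compounds could not show, but the benzyl group lowers the number without abolishing it, since compound 4 still gives 19.3%. Nothing measured here offers an explanation for this fall.

The compounds shown leave open whether the fall belongs to the benzyl group itself or would also appear with a smaller group on the same oxygen, such as methyl or acetyl, or with a longer chain carrying a phenyl ring. They also leave open whether benzyl on the oxygen of compound 3, which carries the hydroxy group and a methyl group on its core, would bring a step of similar size.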